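Para Substituent Swap on a Shared Amide Core

The compounds below may be only part of what the source reports. "The series", "measured", "known", "first", "only" and "open" are said of these compounds alone.

Measured compounds:
Compound 1 `Cc1ccc(-c2ccnc(C(=O)Nc3ccc(Oc4ccnc5[nH]ccc45)cc3)n2)cc1` gives 6140 nM in a functional assay on PC-3 cells (Homo sapiens) for cytotoxicity, read by MTT assay, with a stated time of 72 h; a higher number here means a weaker inhibitor, a lower number a stronger inhibitor.
Compound 2 `COc1ccc(-c2ccnc(C(=O)Nc3ccc(Oc4ccnc5[nH]ccc45)cc3)n2)cc1` gives 17300 nM in this assay.

Compound 2 stands with the highest of the two numbers in this assay; its nearest neighbour is compound 1, and the step of a 2.8-fold higher number from compound 1 to compound 2 (0.45 log units; beyond the scatter) lies beyond the scatter. Compound 3 `O=C(Nc1ccc(Oc2ccnc3[nH]ccc23)cc1)c1nccc(-c2ccc(Cl)cc2)n1` differs from compound 2 in one place: chloro in place of methoxy on an aromatic carbon. Within the data shown here, only one measured step bears on this change, the one between compound 1 and compound 2, which concerns methyl against methoxy and so speaks to the leaving group but not to chloro. The methoxy compound gave the higher number, so taking the methoxy away is expected to bring the number back toward that of compound 1, with a modest step of about a 2.5-fold lower number from compound 2 to compound 3 (0.39 log units; beyond the scatter) expected. Compound 3 is therefore estimated at 7000 nM, with a range from 2500 nM to 20000 nM.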

Compound 3, half-maximal inhibitory concentration: "not active" (no number reported)
Nothing numeric was reported for compound 3, and the estimate cannot be compared.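

Among these compounds, compound 3 is reported only as "not active" in this assay, with no number, so no step from compound 2 to compound 3 can be read. The compounds shown leave open how far the 4-chlorophenyl group separates from the 4-methoxyphenyl group on a numerical scale. No measured evidence bears on this result.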